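Swapping the amide-bound aryl group on an indole azo scaffold

The compounds below may be only part of what the source reports. "The series", "measured", "known", "first", "only" and "open" are said of these compounds alone.

Compound 2 `O=C(Nc1ccccc1F)c1ccc(/N=N\c2c[nH]c3ccccc23)cc1` was measured in a functional assay on P388 cells (Mus musculus) for inhibition, read by MTT assay, with a stated time of 72 h (a higher number here means a weaker inhibitor, a lower number a stronger inhibitor), where compound 2 gives 106000 nM. Among the measured compounds shown here, its only measured neighbour, compound 1 `Cc1ccc(NC(=O)c2ccc(/N=N\c3c[nH]c4ccccc34)cc2)c(C)c1`, gives 190000 nM in this assay; the two lie within the scatter of each other, the step being a 1.8-fold lower number from compound 1 to compound 2 (0.25 log units; within the scatter). Compound 3 `O=C(Nc1ccc([N+](=O)[O-])cc1)c1ccc(/N=N\c2c[nH]c3ccccc23)cc1` differs from compound 2 by 4-nitrophenyl in place of 2-fluorophenyl on an amide-type nitrogen. For the measured compounds named here, the single measured step at the same amide-type nitrogen stayed within the scatter, so for compound 3 no step beyond the scatter is expected, namely a 1.1-fold lower number from compound 2 to compound 3 (0.03 log units; within the scatter). Compound 3 is therefore estimated at 100000 nM, with a range from 40000 nM to 250000 nM.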

Compound 3, half-maximal inhibitory concentration: 11200 nM
Estimate against measurement, compound 3: 8.9-fold (0.95 log units) above, and the stated range ends above it.
By their numbers in this assay, from the lowest: compound 3; then compounds 2 and 1 (each within the scatter of the next).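

The aryl group on the amide-type nitrogen can clearly shift the number in this assay, a point the earlier pair within the scatter could not make. 4-Nitrophenyl gives a step beyond the scatter against 2-fluorophenyl (a 9.5-fold lower number from compound 2 to compound 3 (0.98 log units; beyond the scatter)) and a larger one against 2,4-dimethylphenyl (a 17-fold lower number from compound 1 to compound 3 (1.23 log units; beyond the scatter)). Nothing available explains these steps.

Each step replaces a whole aryl group, so the share of the nitro group itself remains unresolved. From the compounds shown here alone, how a phenyl ring carrying an amine or a carboxylic acid would compare also stays open.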